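Returning to a Phenyl Amide Partner That Carries an Aminomethyl Group

The source may report more compounds than this note shows. Statements on the series, on what has been measured and on what is new or still open speak of the compounds shown alone.

Compound 3 `CNCc1csc(NC(=O)c2cc(C(C)(C)C)nn2Cc2ccccc2)n1` sits at the top of this small set: in a physicochemical assay for solubility, read by nephelometry, measured as kinetic solubility, at pH 2.0 (on this read-out lower numbers stand for lower solubility and higher numbers for higher solubility), compound 3 gives 25 ug/mL, level with compound 2 `CC(C)(C)c1cc(C(=O)Nc2ccccn2)n(Cc2ccccc2)n1` at 25 ug/mL, while compound 1 `CC(C)(C)c1cc(C(=O)Nc2ccccc2)n(Cc2ccccc2)n1` gives 1.6 ug/mL. The step of a 16-fold higher number from compound 1 to compound 3 (1.19 log units; beyond the scatter) and the step of a 16-fold higher number from compound 1 to compound 2 (1.19 log units; beyond the scatter) both show that exchanging the plain phenyl on the amide nitrogen for a pyridin-2-yl or a 4-((methylamino)methyl)-1,3-thiazol-2-yl group raised the number strongly. Compound 4 `CC(C)(C)c1cc(C(=O)Nc2cccc(CN)c2)n(Cc2ccccc2)n1` differs from compound 3 by 3-(aminomethyl)phenyl in place of 4-((methylamino)methyl)-1,3-thiazol-2-yl on an amide-type nitrogen. This returns to a six-membered aromatic ring of carbon only, as in compound 1, yet keeps one hydrogen-bond donor in the aminomethyl group. Among the measured compounds shown here, no measured step covers that group, so the result in this assay is expected to be a step of a 1.3-fold lower number from compound 3 to compound 4 (0.10 log units; within the scatter), within the scatter. Compound 4 is therefore estimated to give about 20 ug/mL, between 5 ug/mL and 80 ug/mL.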

Compound 4, solubility: > 100 ug/mL
Compound 4 was reported as a limit (the forecaster's own chance of this, stated with the estimate: 5%); middle value at least 5.0-fold (0.69 log units) away from the limit.
By their numbers in this assay, from the lowest: compound 1; then compounds 2 and 3 (each within the scatter of the next). At a limit, above all of these: compound 4.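

In this assay the reading for compound 4 is a limit of the assay, not a number: the limit of > 100 ug/mL in this assay, at which 1 of the 4 values shown sits.

On the amide-type nitrogen, 3-(aminomethyl)phenyl outdoes both the 4-((methylamino)methyl)-1,3-thiazol-2-yl and the pyridin-2-yl group, with an at least 4.0-fold higher number from compound 3 to compound 4 (0.60 log units; beyond the scatter) and an at least 4.0-fold higher number from compound 2 to compound 4 (0.60 log units; beyond the scatter). Aminomethyl in place of hydrogen on an aromatic carbon gives an at least 62-fold higher number from compound 1 to compound 4 (1.79 log units; beyond the scatter), so a ring of carbon only does not by itself keep the number low.

As far as these compounds go, the true size of these steps stays open, since the reading stops at a limit. Also open, from the compounds shown here alone, is whether a longer aminoethyl chain or a carboxylic acid in place of the aminomethyl would read the same.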